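Allyl to isobutyl on the amine nitrogen

The compounds below may be only part of what the source reports. "The series", "measured", "known", "first", "only" and "open" are said of these compounds alone.

Compound 1 `CCC(C)NC(=C\C(=O)/C=C/c1ccc(O)c(OC)c1)/C=C/c1ccc(O)c(OC)c1`: > 25000 nM (a limit)
Compound 2 `C=CCNC(=C\C(=O)/C=C/c1ccc(O)c(OC)c1)/C=C/c1ccc(O)c(OC)c1`: > 25000 nM (a limit)

In a functional assay on Caco-2 cells (Homo sapiens) for inhibition, read by sulforhodamine B assay, with a stated time of 72 h (a higher number here means a weaker inhibitor, a lower number a stronger inhibitor), compound 2 gives > 25000 nM as a limit, not a number. Among the compounds with values here, compound 1 and compound 2 both stand at the limit of > 25000 nM in this assay, at which 2 of the 2 values shown sit, so far. The change to compound 3 `COc1cc(/C=C/C(=O)/C=C(/C=C/c2ccc(O)c(OC)c2)NCC(C)C)ccc1O` reads isopropyl in place of vinyl on a saturated chain carbon bound to an amine nitrogen in full; in short, isopropyl in place of vinyl on a saturated chain carbon bound to an amine nitrogen, or allyl to isobutyl. Within the data shown here, the one measured step on this nitrogen is a step that the two limits leave unreadable from compound 1 to compound 2 and has no readable size, so no size or direction carries over to compound 3. Among the measured compounds shown here, the expected change is a number no higher from compound 2 to compound 3 (the limit leaves the size open) in this assay, with no step expected beyond the scatter and no direction favoured. For compound 3 the estimated value is 25000 nM with an expected range from 12000 nM to 50000 nM in this assay, and a further report as a limit is expected.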

Compound 3, half-maximal inhibitory concentration: > 25000 nM
Compound 3 gave a limit, no number (the forecaster's own chance of this, stated with the estimate: 75%); the middle value sits exactly at the limit.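

No step can be read among compound 1, compound 2 and compound 3 in this assay, since all three are reported only as limits: the limit of > 25000 nM in this assay, at which 3 of the 3 values shown sit. The compounds shown leave open whether sec-butyl, allyl and isobutyl on the amine nitrogen differ at all in this read-out.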